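Para-halogen swap on the pendant phenyl: fluoro to chloro

A few compounds are considered here, and "the series" means these few. Any claim that something is new, unique, unknown or untested is made for them only; others in the source may bear on it.

Three compounds of the shared core have numbers in a functional assay on A549 cells (Homo sapiens) for cytotoxicity, read by MTT assay, with a stated time of 72 h; on this read-out lower numbers stand for stronger inhibition and higher numbers for weaker inhibition. Compound 1 `O=C(Nc1ccc(Oc2ccnc3[nH]ccc23)cc1)c1cc(-c2ccc(Cl)cc2)ncn1` gives 6530 nM. Compound 2 `COc1ccc(-c2cc(C(=O)Nc3ccc(Oc4ccnc5[nH]ccc45)c(F)c3)ncn2)cc1` gives 4210 nM, the lowest number of the three. Compound 3 `O=C(Nc1ccc(Oc2ccnc3[nH]ccc23)c(F)c1)c1cc(-c2ccc(F)cc2)ncn1` gives 14200 nM, the highest number of the three, with compound 1 nearest and compound 2 furthest. Among the compounds with values here, the one single-point step is a 3.4-fold higher number from compound 2 to compound 3 (0.53 log units; beyond the scatter).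

Compound 4 `O=C(Nc1ccc(Oc2ccnc3[nH]ccc23)c(F)c1)c1cc(-c2ccc(Cl)cc2)ncn1` differs from compound 3 by chloro in place of fluoro on an aromatic carbon. Within the data shown here, no measured pair shows exactly this change. The step from compound 2 to compound 3 concerns methoxy to fluoro at the same place and does not bear directly on it. Compound 1 carries the chloro group but differs from compound 3 in two places. In this assay, among the measured compounds shown here, compound 1 gives 6530 nM, and set beside the number of compound 3 this shows only that the chloro-bearing compound sits lower; this is not a clean step. The expectation in this assay is therefore a modest move to a lower number, of uncertain size, with a range wide enough to include no change beyond the scatter. Compound 4 is estimated at 7000 nM, between 2800 nM and 17000 nM, an expected step of a 2.0-fold lower number from compound 3 to compound 4 (0.31 log units; beyond the scatter).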

Compound 4, half-maximal inhibitory concentration: 3360 nM
Compound 4: middle estimate off by 2.1-fold (0.32 log units), on the high side, and the stated range covers the measured number.
By their numbers in this assay, from the lowest: compounds 4, 2 and 1 (each within the scatter of the next); then compound 3.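

In this assay, within the data shown here, the change from 4-fluorophenyl to 4-chlorophenyl now has a direct reading, a 4.2-fold lower number from compound 3 to compound 4 (0.63 log units; beyond the scatter), at a position where the earlier compounds gave only a methoxy to fluoro step. With chloro in place of methoxy on this aromatic carbon, the reading is a 1.3-fold lower number from compound 2 to compound 4 (0.10 log units; within the scatter), so these two groups are not separated here, while compound 3 with fluoro stands apart from both. Fluoro in place of hydrogen on an aromatic carbon of the chloro-bearing series gives a 1.9-fold lower number from compound 1 to compound 4 (0.29 log units; within the scatter), so that change is not resolved in this assay, and no measurement accompanies these numbers that could explain any of the steps.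

Still open, on these data alone, is how an amine, a carboxylic acid or a bromo group would compare with chloro and methoxy at this place, para to a large group. As far as these compounds go, it also remains open whether the fluoro to chloro step would keep its size on the core of compound 1, or would appear at all in a read-out other than cell cytotoxicity.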